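The source may report more compounds than this note shows. Statements on the series, on what has been measured and on what is new or still open speak of the compounds shown alone.

Among the compounds with values here, in a functional assay on MOLT-4 cells (Homo sapiens) for inhibition, read by MTT assay, with a stated time of 72 h (a higher number here means a weaker inhibitor, a lower number a stronger inhibitor), compound 2 `COc1cc(NC(C)CCCNC(=O)Nc2ccc(C(F)(F)F)cc2)c2ncccc2c1` gives 20000 nM, the lower of the two numbers measured so far, while compound 1 `COc1cc(NC(C)CCCNC(=O)NNC(=O)Nc2ccc(Br)cc2)c2ncccc2c1` gives 209000 nM. The next structure, compound 3 `COc1cc(NC(C)CCCNC(=O)NNC(=O)Nc2ccc(O)cc2)c2ncccc2c1`, changes compound 2 at one place, on an amide-type nitrogen: ((4-hydroxyphenyl)carbamoyl)amino in place of 4-(trifluoromethyl)phenyl on an amide-type nitrogen. In words, ((4-hydroxyphenyl)carbamoyl)amino stands in place of 4-(trifluoromethyl)phenyl. Within the data shown here, one measured step bears on this, a 10-fold lower number from compound 1 to compound 2 (1.02 log units; beyond the scatter). It is large and beyond the scatter, and it runs the opposite way, although its group carries 4-bromophenyl rather than 4-hydroxyphenyl. What that ring difference does on its own has not been measured. A large move back towards a weaker inhibitor is therefore expected, and the expected change is a 7.5-fold higher number from compound 2 to compound 3 (0.88 log units; beyond the scatter). For compound 3 the estimated value is 150000 nM, with an expected range of 60000 nM to 400000 nM.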

Compound 3, half-maximal inhibitory concentration: 104000 nM
The estimate for compound 3 lay 1.4-fold (0.16 log units) above the measured number; the measured number falls inside the stated range.
By their numbers in this assay, from the lowest: compound 2; then compounds 3 and 1 (each within the scatter of the next).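

Putting ((4-hydroxyphenyl)carbamoyl)amino in place of 4-(trifluoromethyl)phenyl on the amide-type nitrogen gives a 5.2-fold higher number from compound 2 to compound 3 (0.72 log units; beyond the scatter) and so repeats, with a different ring substituent, the direction already seen between compound 1 and compound 2. Hydroxy in place of bromo on an aromatic carbon gives a 2.0-fold lower number from compound 1 to compound 3 (0.30 log units; within the scatter) and is the first direct reading of that ring change. For these two compounds, then, the higher number goes with the longer carbamoylamino group whichever of the two ring substituents it carries, and the swap between them makes no readable difference. Going by these compounds, whether an amine or a carboxylic acid on that ring would behave the same way remains open. Why the longer group goes with the higher number also stays unexplained, as no supporting evidence is available.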